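Benzyloxy to (carboxymethyl)amino on the long-chain amine

This account rests on a few compounds, and the source may have more. Where it says the series, first, only, none or still open, it means among the compounds named here.

Measured so far:
- compound 1 `CCCCCCCCCCCCCCC(N)COCc1ccccc1` gives 3000 nM
- compound 2 `CCCCCCCCCCCCCCC(COCc1ccccc1)N(CC)CC` gives 20000 nM

In a functional assay on Jurkat cells (Homo sapiens) for inhibition (on this read-out lower numbers stand for stronger inhibition and higher numbers for weaker inhibition), compound 1 stands at the lower of the two numbers. Going by the values given here, the single measured step, a 6.7-fold higher number from compound 1 to compound 2 (0.82 log units; beyond the scatter), concerns the amine only and shows that building out the amine weakens inhibition in this assay.

Compound 3 `CCCCCCCCCCCCCCC(N)CNCC(=O)O` differs from compound 1 by (carboxymethyl)amino in place of benzyloxy on a saturated chain carbon, two bonds along the chain from an amine nitrogen. Among the compounds with values here, no measured step touches this position; the step from the amine change does not bear on the benzyloxy end of the molecule. The expectation for compound 3 therefore rests on compound 1 alone, whose value is 3000 nM, and must be given a wide range. A step of a 2.0-fold higher number from compound 1 to compound 3 (0.30 log units; within the scatter) is estimated, with no firm direction beyond the scatter. Compound 3 is expected at 6000 nM, within the range 1000 nM to 40000 nM.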

Compound 3, half-maximal inhibitory concentration: 31000 nM
Beside the measured number, compound 3's estimate is 5.2-fold (0.71 log units) below it; the range from low to high includes it.
By their numbers in this assay, from the lowest: compound 1; then compounds 2 and 3 (each within the scatter of the next).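

The benzyloxy end of the molecule is not neutral in this assay: (carboxymethyl)amino in place of benzyloxy gives a 10-fold higher number from compound 1 to compound 3 (1.01 log units; beyond the scatter) and so counts as a large step. This shows that inhibition depends on this position as well as on the amine, the only site changed in the earlier pair. The change removes the six-membered aromatic ring and adds a double bond outside aromatic rings, but no measurement on hand links either feature to the step.

This single exchange does not separate the loss of the benzyloxy group from the entry of the (carboxymethyl)amino group; a hydroxyl or benzylamino group on the same saturated chain carbon would bear on that question. Also open, from the compounds shown here alone, is how a shorter chain would change inhibition with each of these end groups.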